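This account rests on a few compounds, and the source may have more. Where it says the series, first, only, none or still open, it means among the compounds named here.

Compound 2 `O[C@H](COCCOC[C@@H](O)Cc1cn(-c2cccs2)nn1)Cc1ccc(-c2ccccc2)cc1` gives 33400 nM in a functional assay on SGC-7901 cells (Homo sapiens) for inhibition, read by MTT assay, with a stated time of 72 h (on this read-out lower numbers stand for stronger inhibition of growth and higher numbers for weaker inhibition of growth), the highest of the three numbers at hand. Its nearest neighbour is compound 3 `O[C@H](COCCOC[C@@H](O)Cc1cn(-c2cccnc2)nn1)Cc1ccc(-c2ccccc2)cc1`, which in this assay gives 29800 nM; the two are separated by a 1.1-fold lower number from compound 2 to compound 3 (0.05 log units; within the scatter), a gap within the scatter. Compound 1 `CC1=C(CCCCCCCCCCn2cc(C[C@H](O)COCCOC[C@@H](O)Cc3ccc(-c4ccccc4)cc3)nn2)C(=O)c2ccccc2C1=O`, which carries a much larger group on the aromatic nitrogen, stands furthest away and gives 390 nM in this assay, far below compound 2 and beyond the scatter.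

Compound 4 `O[C@H](COCCOC[C@@H](O)Cc1cn(-c2ccc3[nH]ccc3c2)nn1)Cc1ccc(-c2ccccc2)cc1` differs from compound 2 in one place: 1H-indol-5-yl in place of thiophen-2-yl on an aromatic nitrogen. For the measured compounds named here, the only measured step that bears directly on this change is a 1.1-fold lower number from compound 2 to compound 3 (0.05 log units; within the scatter), where one small aromatic group replaced another on the aromatic nitrogen and the number hardly moved. Going by the values given here, the values of compound 1 and compound 2 show that a large group on the aromatic nitrogen can go with a much lower number, but no single step joins those two structures, and the 1H-indol-5-yl group is nothing like the group of compound 1. A modest step downward is therefore expected, a 1.9-fold lower number from compound 2 to compound 4 (0.27 log units; within the scatter), which may not reach beyond the scatter. Compound 4 is estimated to give 18000 nM in this assay, with a range from 6000 nM to 45000 nM.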

Compound 4, concentration for 50% growth inhibition: 45600 nM
Estimate against measurement, compound 4: 2.5-fold (0.40 log units) below; measured number outside the range, above it.
By their numbers in this assay, from the lowest: compound 1; then compounds 3, 2 and 4 (each within the scatter of the next).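

Placing 1H-indol-5-yl on the aromatic nitrogen, with 9 heavy atoms against the 5 of thiophen-2-yl and 1 hydrogen-bond donor where thiophen-2-yl has 0, gives a 1.4-fold higher number from compound 2 to compound 4 (0.14 log units; within the scatter) in this assay, while the exchange for pyridin-3-yl gives a 1.5-fold higher number from compound 3 to compound 4 (0.18 log units; within the scatter). For the compounds shown here, the earlier step covered only two single aromatic rings, whereas these steps show that a group with a second aromatic ring also cannot be told apart from them at this position on this read-out. The added ring and donor therefore do not by themselves bring compound 4 close to compound 1, which gives 390 nM, and nothing at hand explains why these three aromatic groups stay so close together.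

On these data alone, it remains open whether a longer chain alone on the aromatic nitrogen, or such a chain ending in an amine, would bring the number nearer to that of compound 1. As far as these compounds go, it is also open whether a carboxylic acid on the aromatic group would separate a compound from compound 2, compound 3 and compound 4.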